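The source may report more compounds than this note shows. Statements on the series, on what has been measured and on what is new or still open speak of the compounds shown alone.

Compound 1 `CCCOC(=O)C1=C(C)NC(=S)NC1c1ccsc1` gives 1% in an assay on membranes from HeLa cells for displacement of a labelled ligand from adenosine receptor A3 (Homo sapiens), read by scintillation counting, with a stated time of 180 min, tested at 1 uM; a higher number here means more inhibition at the concentration tested (going by the name of the read-out), a lower number less inhibition. Compound 2 `CC1=C(C(=O)OCC(C)C)C(c2ccsc2)NC(=S)N1` carries the change (methyl in place of hydrogen on a saturated chain carbon bound to two saturated chain carbons), and the step of a number 1 percentage points higher from compound 1 to compound 2 (within the scatter) is small. Compound 3 `CCSC(=O)C1=C(C)NC(=O)NC1c1ccsc1` has a different core; the difference between the two cores is not broken down here. In this assay compound 3 gives 2%, while compound 2 gives 2%. Compound 4 `CC1=C(C(=O)SC(C)C)C(c2ccsc2)NC(=O)N1` is not yet measured and differs from compound 3 by methyl in place of hydrogen on a saturated chain carbon bound to a saturated chain carbon and a sulfur. Within the data shown here, this is the same kind of change as the one from compound 1 to compound 2, though the place differs: there the carbon was bound to two saturated chain carbons, here to a saturated chain carbon and a sulfur. Because the earlier step of a number 1 percentage points higher from compound 1 to compound 2 (within the scatter) stayed within the scatter, the expected step of no change at the digits printed from compound 3 to compound 4 (within the scatter) is likewise small. Compound 4 is therefore estimated at 2%, expected to lie between 0% and 8%.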

Compound 4, a percentage reported as inhibition, at one concentration (the size of the read-out at that concentration, not a potency): 1%
Compound 4: the middle estimate sits 1 percentage points above what was measured; the measured number falls inside the stated range.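

In this assay the change from ethylsulfanyl to isopropylsulfanyl gives a number 1 percentage points lower from compound 3 to compound 4 (within the scatter) and this step is small. Set beside the earlier step, adding this methyl reads alike on the two cores: the same change on two cores in this assay, a number 1 percentage points higher (within the scatter) from compound 1 to compound 2 and a number 1 percentage points lower (within the scatter) from compound 3 to compound 4, 2 percentage points apart, within the scatter of two such steps. This does not show how the change would behave on a compound with clear inhibition: all four compounds read low at the one concentration tested, and such readings give no potency.

The compounds shown leave open what a longer chain, an amine or a carboxylic acid in place of the isopropyl would do. They also leave open whether any such group would give clear inhibition in this assay on either core.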